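The source may hold more compounds than are shown below. What is called first, only, known or untested is meant among the compounds shown, and "the series" means these compounds.

Measured compounds:
Compound 1 `O=C(CSc1nc2c(c(=O)n1-c1ccccc1)SCC2)Nc1ccc(-c2ccncc2)cc1` — 3 nM
Compound 2 `Cc1ccc2nc(NC(=O)CSc3nc4c(c(=O)n3-c3ccc(F)cc3)SCC4)sc2c1` — 40 nM

In an assay on L cells for inhibition of Protein-serine O-palmitoleoyltransferase porcupine (Mus musculus), read by reporter gene assay, with a stated time of 24 h (on this read-out higher numbers stand for an effect only at larger amounts of compound and lower numbers for an effect already at smaller amounts), compound 1 gives 3 nM, the lower of the two numbers shown. Compound 2 gives 40 nM in this assay, a gap that lies beyond the usual scatter. Compound 3 `CCOC(=O)c1ccc(NC(=O)CSc2nc3c(c(=O)n2-c2ccccc2)SCC3)cc1` has not yet been measured. It keeps the shared core of compound 1 and differs in one place: ethoxycarbonyl in place of pyridin-4-yl on an aromatic carbon. Going by the values given here, no step of this kind has been measured here, so the expectation rests on compound 1 alone. Among the compounds with values here, a moderate rise in the number is expected, since the sole measured change away from compound 1, to compound 2, moved the number upward, though that change sat elsewhere in the molecule. The estimated step from compound 1 to compound 3 is a 10-fold higher number from compound 1 to compound 3 (1.00 log units; beyond the scatter). Compound 3 is therefore expected to give about 30 nM in this assay, within a range from 5 nM to 200 nM.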

Compound 3, half-maximal effective concentration: 300 nM
Compound 3: the middle estimate sits 10-fold (1.00 log units) below what was measured; the whole stated range lies below it.
By their numbers in this assay, from the lowest: compound 1; then compound 2; then compound 3.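

In this assay, going by these compounds alone, putting ethoxycarbonyl in place of pyridin-4-yl produces a 100-fold higher number from compound 1 to compound 3 (2.00 log units; beyond the scatter) in a single change, the first step here that can be read at one place in the molecule. This position, on the six-membered aromatic ring of carbon only and para to a large group, is therefore far from indifferent to what sits on it: a group with a nitrogen-containing aromatic ring gives way to one with no ring, and the number climbs steeply. No measurement at hand gives a reason for the size of this step.

As far as these compounds go, whether the ring or its nitrogen matters remains open, and a plain phenyl or a pyridin-3-yl at this position would help separate the two. From the compounds shown here alone, it is also open whether a carboxylic acid or a simple amide here would behave more like ethoxycarbonyl or more like pyridin-4-yl.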